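This account rests on a few compounds, and the source may have more. Where it says the series, first, only, none or still open, it means among the compounds named here.

Of the compounds shown here, three sharing one core have been measured in a functional assay on UACC-257 cells (Homo sapiens) for inhibition, read by sulforhodamine B assay, with a stated time of 48 h, tested at 0.1 uM; on this read-out lower numbers stand for a stronger effect and higher numbers for a weaker effect at the one concentration tested. Compound 1 `O=C(Nc1cccc(-n2cc(-c3ccncc3)c(-c3cc(O)cc(Cl)c3)n2)c1)Nc1ccc(Cl)c(C(F)(F)F)c1` gives 91% in this assay. Going by the values given here, compound 2 `O=C(Nc1cccc(-n2cc(-c3ccncc3)c(-c3cc(O)cc(Cl)c3)n2)c1)Nc1ccc(Cl)c(Cl)c1` gives 91% in this assay, and the only one-place step measured so far shows no change at the digits printed from compound 1 to compound 2 (within the scatter). Compound 3 `COc1cc(Cl)cc(-c2nn(-c3cccc(NC(=O)Nc4cc(C(F)(F)F)cc(C(F)(F)F)c4)c3)cc2-c2ccncc2)c1` gives 94% in this assay, the highest of the three numbers, though its gaps to compound 1 and to compound 2 both lie within the scatter, so compound 3 cannot be set apart from either.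

Compound 4 `COc1cc(Cl)cc(-c2nn(-c3cccc(NC(=O)Nc4cccc(C(F)(F)F)c4)c3)cc2-c2ccncc2)c1` has not yet been measured. It differs from compound 3 in one place: hydrogen in place of trifluoromethyl on an aromatic carbon. Among the compounds with values here, no measured step removes a trifluoromethyl outright. Within the data shown here, the one step touching a trifluoromethyl, no change at the digits printed from compound 1 to compound 2 (within the scatter), exchanges it for chloro and leaves the number unchanged. On that basis compound 4 is expected to stay close to compound 3, with an expected step of a number 2 percentage points lower from compound 3 to compound 4 (within the scatter) that does not exceed the scatter. Compound 4 is therefore estimated at 92%, in a range from 78% to 100%.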

Compound 4, a percentage reported as activity, at one concentration (the size of the read-out at that concentration, not a potency): 94%
Compound 4: the middle estimate sits 2 percentage points below what was measured, within the range that was stated.
By their numbers in this assay, from the lowest: compounds 1, 2, 3 and 4 (each within the scatter of the next).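

In this assay, taking the trifluoromethyl off the aromatic carbon, meta to a trifluoromethyl group, and leaving hydrogen there gives no change at the digits printed from compound 3 to compound 4 (within the scatter). The earlier step on a trifluoromethyl replaced that group with chloro, no change at the digits printed from compound 1 to compound 2 (within the scatter), whereas this one shows that at this position, with 4 heavy atoms gone and no heavy atom entering, the read-out at the one concentration tested still cannot tell the two compounds apart. No evidence is available that bears on this result. From the compounds shown here alone, what an amine or a carboxylic acid on this carbon would do in this assay remains open. Also open, going by these compounds, is whether compound 3 and compound 4 would stay indistinguishable at another concentration.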